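The compounds below may be only part of what the source reports. "The series", "measured", "known", "first", "only" and "open" are said of these compounds alone.

Measured compounds:
- compound 1 `C[C@@H]1CN(c2cccc3c2C[C@H](CN(C)[C@H]2CCCc4cccnc42)NC3)C[C@H](C)N1`: 61 nM
- compound 2 `Cc1cnc(CN(C)C[C@H]2Cc3c(cccc3N3CCNCC3)CN2)c(C)c1`: 21.4 nM

Two compounds carry numbers in a functional assay on CCRF-CEM cells for antagonist activity at C-X-C chemokine receptor type 4 (Homo sapiens), read by calcium flux, with stated times of 25 min and 90 s; on this read-out higher numbers stand for weaker inhibition and lower numbers for stronger inhibition. Compound 1 gives 61 nM and stands highest of the two numbers; its nearest neighbour, compound 2, gives 21.4 nM, a lower number, and the gap lies beyond the usual scatter. For the measured compounds named here, the two differ in more than one place, so what they show is only that compound 2 inhibits more strongly, not which part of the structure is responsible.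

Compound 3 `CC(C)N1CCN(c2cccc3c2C[C@H](CN(C)[C@H]2CCCc4cccnc42)NC3)CC1` has not been measured. It differs from compound 1 in one place: 4-isopropylpiperazin-1-yl in place of 3,5-dimethylpiperazin-1-yl on an aromatic carbon. Going by the values given here, no pair of measured compounds differs only in this way, so there is no measured step to lean on, and the expectation rests on compound 1 alone at 61 nM together with the absence of a guiding comparison.

The step from compound 1 to compound 3 is expected to be a 1.1-fold higher number from compound 1 to compound 3 (0.06 log units; within the scatter), that is, no step beyond the scatter in either direction. Compound 3 is expected at 70 nM, with a range from 20 nM to 250 nM.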

Compound 3, half-maximal inhibitory concentration: 16.9 nM
The estimate for compound 3 lay 4.1-fold (0.62 log units) above the measured number; the measured number lies below the stated range.
By their numbers in this assay, from the lowest: compounds 3 and 2 (each within the scatter of the next); then compound 1.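

In this assay, the aromatic carbon of the shared core that carries the piperazine ring accepts a change in how that ring is substituted: 4-isopropylpiperazin-1-yl in place of 3,5-dimethylpiperazin-1-yl gives a 3.6-fold lower number from compound 1 to compound 3 (0.56 log units; beyond the scatter), so inhibition strengthens rather than being lost. For the compounds shown here, this is the only step that changes a single place, and it shows that this position affects the read-out, which the comparison of the two earlier compounds could not show. The exchange removes both ring-carbon methyl groups, adds an isopropyl group on the ring nitrogen and takes the group from 1 hydrogen-bond donor to 0, but no measurement available here bears on which of these changes matters or why.

With one step, the methyl removal and the isopropyl addition cannot be separated, and 4-methylpiperazin-1-yl on the core of compound 1 would be the direct test of how much of the alkyl group on nitrogen is needed. As far as these compounds go, whether the ring nitrogen is needed at all remains open, a question that morpholin-4-yl at the same aromatic carbon would address.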